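Replacing heptyl with 2-(4-methoxyphenyl)ethenyl

The source may hold more compounds than are shown below. What is called first, only, known or untested is meant among the compounds shown, and "the series" means these compounds.

Of the compounds shown here, three sharing one core have been measured in a functional assay on cells (T-cell line, Homo sapiens) for inhibition (on this read-out lower numbers stand for stronger inhibition and higher numbers for weaker inhibition), so far. Compound 1 `CN1CCC(COC(c2ccccc2)c2ccccc2)CC1` returns only a limit of the assay (> 20000 nM). Compound 2 `CCCCCCCN1CCC(COC(c2ccccc2)c2ccccc2)CC1` gives 500 nM and compound 3 `CCCCCCCCN1CCC(COC(c2ccccc2)c2ccccc2)CC1` gives 700 nM in this assay as numbers proper. These two values lie within the scatter of each other (a 1.4-fold higher number from compound 2 to compound 3 (0.15 log units; within the scatter)), so compound 3 stands level with compound 2. Both lie far from the limit of compound 1, with an at least 40-fold lower number from compound 1 to compound 2 (1.60 log units; beyond the scatter) and an at least 28-fold lower number from compound 1 to compound 3 (1.45 log units; beyond the scatter) on record.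

Compound 4 `COc1ccc(/C=C/CN2CCC(COC(c3ccccc3)c3ccccc3)CC2)cc1` has not yet been measured. It carries 2-(4-methoxyphenyl)ethenyl in place of heptyl on a saturated chain carbon bound to an amine nitrogen in a ring. For the measured compounds named here, no measured compound has an aromatic ring in this substituent, so the measured steps bear on the change only indirectly. The large step of an at least 28-fold lower number from compound 1 to compound 3 (1.45 log units; beyond the scatter) shows how much rides on the substituent at this place, while the small step of a 1.4-fold higher number from compound 2 to compound 3 (0.15 log units; within the scatter) shows one chain length exchanged with no change beyond the scatter. Compound 4 also keeps a large substituent there, so a return to the limit is not expected. A modest rise is expected instead, with the estimated step being a 1.4-fold higher number from compound 3 to compound 4 (0.15 log units; within the scatter) in this assay overall. The estimated value for compound 4 is 1000 nM with an expected span from 250 nM to 4000 nM as its range.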

Compound 4, half-maximal inhibitory concentration: 4300 nM
Estimate against measurement, compound 4: 4.3-fold (0.63 log units) below, and the stated range ends below it.
By their numbers in this assay, from the lowest: compounds 2 and 3 (each within the scatter of the next); then compound 4. At a limit, above all of these: compound 1.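

In this assay, the place on a saturated chain carbon bound to an amine nitrogen in a ring responds to the kind of substituent and not only to its presence: a 6.1-fold higher number from compound 3 to compound 4 (0.79 log units; beyond the scatter) and an 8.6-fold higher number from compound 2 to compound 4 (0.93 log units; beyond the scatter) both lie beyond the scatter, whereas the exchange of one chain length stayed within it. The entering 2-(4-methoxyphenyl)ethenyl, with its six-membered aromatic ring and its double bond outside that ring, still keeps much of what a large substituent gives here, with an at least 4.6-fold lower number from compound 1 to compound 4 (0.66 log units; beyond the scatter), which places its number above those of the two alkyl-bearing compounds and short of the limit. The size of that last step remains a bound, since compound 1 stands at a limit of the assay: the limit of > 20000 nM in this assay, at which 1 of the 4 values shown sits.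

The compounds shown leave open which part of the entering group carries the rise: the aromatic ring, the double bond or the methoxy group. They also leave open how a plain phenyl group, a chain shorter than hexyl, or a heptyl chain ending in an amine or a carboxylic acid would read in this assay.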